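The compounds below may be only part of what the source reports. "The series", "measured", "known", "first", "only" and "open" are said of these compounds alone.

Of the compounds shown here, three have so far been measured in an assay on isolated protein for displacement of a labelled ligand from metabotropic glutamate receptor 5 (Homo sapiens), with a stated time of 60 min, tested at 1 uM; a higher number here means more inhibition at the concentration tested (going by the name of the read-out), a lower number less inhibition. Compound 1 `Cc1ccc(S(=O)(=O)c2cnc3ccc(Cl)cc3c2N2CCC(C)CC2)cc1C` gives 84% in this assay. Compound 2 `CC1CCN(c2c(S(=O)(=O)c3ccc(C#N)cc3)cnc3ccc(Cl)cc23)CC1`, which carries a 4-cyanophenyl in place of 3,4-dimethylphenyl on the sulfonyl sulfur, gives 31%; the change brought a number 53 percentage points lower from compound 1 to compound 2 (beyond the scatter). Compound 3 `CC1CCN(c2c(S(=O)(=O)c3cccc(C#N)c3)cnc3ccc(F)cc23)CC1` gives 93%. Its number lies close to that of compound 1, a gap within the usual scatter, while compound 2 lies well below it, beyond the scatter.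

Compound 4 `CC1CCN(c2c(S(=O)(=O)c3cccc(C#N)c3)cnc3ccc(Cl)cc23)CC1` differs from compound 3 only in this: chloro in place of fluoro on an aromatic carbon. Going by the values given here, no measured step bears on this change. Among the compounds with values here, the one measured step swaps the group on the sulfonyl sulfur, and compounds 1 and 2, which do carry chloro at this place, also carry a different group on the sulfonyl sulfur than compound 3, so no clean comparison exists. With no guidance from the data, the step from compound 3 to compound 4 is expected to stay within the scatter, as a number 5 percentage points lower from compound 3 to compound 4 (within the scatter). Compound 4 is therefore estimated at 88%, with a range from 70% to 98%.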

Compound 4, a percentage reported as inhibition, at one concentration (the size of the read-out at that concentration, not a potency): 90%
The estimate for compound 4 lay 2 percentage points below the measured number, within the range that was stated.
By their numbers in this assay, from the lowest: compound 2; then compounds 1, 4 and 3 (each within the scatter of the next).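

Within this assay, the halogen swap gives a number 3 percentage points lower from compound 3 to compound 4 (within the scatter) and so barely registers: with a 3-cyanophenyl on the sulfonyl sulfur, chloro and fluoro on this aromatic carbon cannot be told apart. Going by these compounds alone, with chloro held constant, compound 4 also gives the first direct comparison of the two cyanophenyl groups, showing a number 59 percentage points higher from compound 2 to compound 4 (beyond the scatter) for the 3-cyanophenyl over the 4-cyanophenyl. Against the 3,4-dimethylphenyl, the same group gives a number 6 percentage points higher from compound 1 to compound 4 (within the scatter) and so leaves the read-out level. Nothing available explains why these swaps matter or fail to matter.

On these data alone, whether a methoxy group or an amine on this aromatic carbon would hold the number as well as the two halogens remains open. So does whether swapping chloro for fluoro would stay as quiet with a 4-cyanophenyl on the sulfonyl sulfur.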